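Chloro to Bromo: Little Change Expected in Cytotoxicity

This account rests on a few compounds, and the source may have more. Where it says the series, first, only, none or still open, it means among the compounds named here.

Measured compounds:
compound 1 `Cc1c(C(=O)/C=C/c2ccc(Cl)cc2)[n+]([O-])c2ccccc2[n+]1[O-]`: 19000 nM
compound 2 `COc1ccc(/C=C/C(=O)c2c(C)[n+]([O-])c3ccccc3[n+]2[O-])cc1OC`: 38000 nM
compound 3 `COc1cc(/C=C/C(=O)c2c(C)[n+]([O-])c3ccccc3[n+]2[O-])cc(OC)c1OC`: 6500 nM

In a functional assay on HSC-4 cells (Homo sapiens) for cytotoxicity, with a stated time of 48 h (a lower number here means that less compound is tolerated, a higher number that more compound is tolerated), compound 1 gives 19000 nM. The value of compound 2 lies within the scatter of that of compound 1, while compound 3 sits at a number lower by an amount beyond the scatter. Compound 4 `Cc1c(C(=O)/C=C/c2ccc(Br)cc2)[n+]([O-])c2ccccc2[n+]1[O-]` differs from compound 1 in one place: bromo in place of chloro on an aromatic carbon. Among the compounds with values here, the only step measured so far, a 5.8-fold lower number from compound 2 to compound 3 (0.77 log units; beyond the scatter), concerns methoxy in place of hydrogen and therefore says nothing about exchanging one halogen for another. Within the data shown here, no measured step bears on this change, so the expectation is a step of no size beyond the scatter, no change at the digits printed from compound 1 to compound 4 (within the scatter). Compound 4 is thus estimated at 19000 nM, between 8000 nM and 45000 nM.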

Compound 4, half-maximal cytotoxic concentration: 36000 nM
Beside the measured number, compound 4's estimate is 1.9-fold (0.28 log units) below it; measured number inside the range.
By their numbers in this assay, from the lowest: compound 3; then compounds 1, 4 and 2 (each within the scatter of the next).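

Bromo in place of chloro on this aromatic carbon, para to a large group, gives a 1.9-fold higher number from compound 1 to compound 4 (0.28 log units; within the scatter) in this assay. At this position, then, the two halogens cannot be told apart in this measurement, and the exchange does not produce a step as clear as the one seen with methoxy. No further measurement shown here offers an explanation for this result. On these data alone, it remains open whether a group of another kind here, such as an amine or a carboxylic acid, would shift the number beyond the scatter. As far as these compounds go, the effect of fluoro at this position is equally open.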